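A few compounds are considered here, and "the series" means these few. Any claim that something is new, unique, unknown or untested is made for them only; others in the source may bear on it.

Compound 1 `COc1ccc(-c2cc(/C=C/C(=O)c3ccc(N)cc3)[nH]n2)cc1`, compound 2 `COc1ccc(-c2cc(/C=C/C(=O)c3ccc(N)cc3)[nH]n2)cc1OC` and compound 3 `COc1cc(C(=O)/C=C/c2cc(-c3cc(OC)c(OC)c(OC)c3)n[nH]2)cc(OC)c1OC` were all tested in a functional assay on SK-OV-3 cells (Homo sapiens) for cytotoxicity, read by sulforhodamine B assay, with a stated time of 48 h, tested at 1 uM; on this read-out higher numbers stand for a weaker effect at the one concentration tested and lower numbers for a stronger effect. There compound 1 gives 105%, compound 2 gives 97% and compound 3 gives 96%. Between compound 2 and compound 1 the change is hydrogen in place of methoxy on an aromatic carbon, and the step it made in this assay is a number 8 percentage points higher from compound 2 to compound 1 (within the scatter). Compound 3 stands nearest to compound 2 and furthest from compound 1, but all three numbers lie within the scatter of one another, so no order among them can be read from these values. The difference between the cores of compound 3 and compound 2 is not broken down here.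

Compound 4 `COc1ccc(-c2cc(/C=C/C(=O)c3cc(OC)c(OC)c(OC)c3)[nH]n2)cc1OC` has not yet been measured. It differs from compound 3 by hydrogen in place of methoxy on an aromatic carbon. Among the compounds with values here, this is the same kind of change as the one from compound 2 to compound 1, but the surroundings differ: here the place is also meta to a methoxy group. Because the earlier step was a number 8 percentage points higher from compound 2 to compound 1 (within the scatter), the step expected in this assay is a number 4 percentage points higher from compound 3 to compound 4 (within the scatter), essentially no movement. Compound 4 is thus estimated to give 100%, between 90% and 112%.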

Compound 4, a percentage reported as activity, at one concentration (the size of the read-out at that concentration, not a potency): 87%
For compound 4 the middle estimate is 13 percentage points above the measured one; measured number outside the range, below it.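

In this assay, putting hydrogen in place of methoxy on the core of compound 3 gave a number 9 percentage points lower from compound 3 to compound 4 (within the scatter), so this step alone does not separate the two compounds. Set beside the earlier step, however, the same change did not carry over from one core to the other with the same size and direction: the same change on two cores in this assay, a number 8 percentage points higher (within the scatter) from compound 2 to compound 1 and a number 9 percentage points lower (within the scatter) from compound 3 to compound 4, 17 percentage points apart, beyond the scatter of two such steps. This shows that, in this small set, a step read on one core is a poor guide to the step on the other, but it rests on a single pair per core and does not show which difference between the cores sets the two steps apart.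

The compounds shown leave open whether the same gap between the steps would appear at other concentrations or on further pairs of cores. They also leave open how a carboxylic acid, a fluorine atom or an ethoxy group in that place would read in this assay.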